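Compound 2 to compound 3: a new ring with a side chain

The source may hold more compounds than are shown below. What is called first, only, known or untested is meant among the compounds shown, and "the series" means these compounds.

Compound 2 `CNC(=O)c1nnc(NC(=O)C2CC2)cc1Nc1cccc(-c2ccncn2)c1OC` stands at 48% in an ADME assay on microsomes from liver (Homo sapiens) for metabolic stability, with a stated time of 10 min (on this read-out lower numbers stand for a less stable compound and higher numbers for a more stable compound), within the scatter of compound 1 `CNC(=O)c1nnc(NC(=O)C2CC2)cc1Nc1cccc(-c2cnccn2)c1OC` at 58%. Compound 3 `CNC(=O)c1nnc(NC(=O)C2CC2)cc1Nc1cccc(-c2cnc(C(C)(C)O)cn2)c1OC` differs from compound 2 at one place, with 5-(1-hydroxy-1-methylethyl)pyrazin-2-yl in place of pyrimidin-4-yl on an aromatic carbon. Among the measured compounds shown here, only one measured step bears on this change. That step, a number 10 percentage points lower from compound 1 to compound 2 (within the scatter), exchanges pyrazin-2-yl for pyrimidin-4-yl and stays within the scatter. For the measured compounds named here, it hints that the ring exchange alone matters little, but no measured compound carries the 1-hydroxy-1-methylethyl group, so the range must stay wide. In this assay the estimated step is a number 7 percentage points higher from compound 2 to compound 3 (within the scatter), a small rise that is expected to stay within the scatter. The estimate for compound 3 is 55%, with an expected range from 35% to 77%.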

Compound 3, percent of the compound remaining: 95%
Beside the measured number, compound 3's estimate is 40 percentage points below it, outside the stated range (above it).
By their numbers in this assay, from the lowest: compounds 2 and 1 (each within the scatter of the next); then compound 3.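

In this assay, among the compounds shown here, the earlier compounds showed only that exchanging one bare ring for another gave a change within the scatter, and this result shows that the same position can give a far larger response: a number 47 percentage points higher from compound 2 to compound 3 (beyond the scatter). With pyrazin-2-yl kept, 1-hydroxy-1-methylethyl in place of hydrogen on an aromatic carbon gives a number 37 percentage points higher from compound 1 to compound 3 (beyond the scatter), so the rise appears without any ring exchange and comes with the side chain alone. Nothing available explains why this side chain raises the number so much.

The compounds shown leave open whether the hydroxy group or the two methyl groups carry the rise, a question that an isopropyl group or an amine in the same place could answer. They also leave open whether 1-hydroxy-1-methylethyl on a pyrimidin-4-yl ring would give a similar rise.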